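From 3,5-dichlorophenyl to 3,4-dichlorophenyl in the series

The source may hold more compounds than are shown below. What is called first, only, known or untested is meant among the compounds shown, and "the series" means these compounds.

In a functional assay on HL-60 cells (Homo sapiens) for inhibition, read by MTT assay, with a stated time of 72 h (a lower number here means a stronger inhibitor, a higher number a weaker inhibitor), three compounds share one core and differ only in the aryl group on the amine nitrogen in a ring. Compound 1 `Cc1ccc(N2CCN(C(=O)c3oc(C)nc3-c3ccccc3)CC2)c(C)c1` gives 101 nM. Compound 2 `Cc1nc(-c2ccccc2)c(C(=O)N2CCN(c3ccc(F)cc3)CC2)o1` reads > 1000 nM, which is a limit of the assay and not a number. Compound 3 `Cc1nc(-c2ccccc2)c(C(=O)N2CCN(c3cc(Cl)cc(Cl)c3)CC2)o1` gives 41.8 nM, the lowest number in the set, and its steps to both other compounds lie beyond the scatter.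

The next change leads to compound 4 `Cc1nc(-c2ccccc2)c(C(=O)N2CCN(c3ccc(Cl)c(Cl)c3)CC2)o1`, with 3,4-dichlorophenyl in place of 3,5-dichlorophenyl on an amine nitrogen in a ring.

Three measured steps change this same group. The first is modest: a 2.4-fold lower number from compound 1 to compound 3 (0.38 log units; beyond the scatter). The second is large: an at least 23-fold lower number from compound 2 to compound 3 (1.37 log units; beyond the scatter). The third is an at least 9.9-fold higher number from compound 1 to compound 2 (0.99 log units; beyond the scatter). None of them only relocates a chlorine, so they show how far this group can shift the number and do not fix the size of the present change. Neither the 2,4-dimethylphenyl of compound 1 nor the 4-fluorophenyl of compound 2 matched compound 3, so a modest rise is expected in this assay, with a wide margin.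

The expected step is a 2.0-fold higher number from compound 3 to compound 4 (0.31 log units; beyond the scatter). For compound 4 the estimated value is 85 nM, with an expected range from 25 nM to 400 nM.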

Compound 4, half-maximal inhibitory concentration: 124 nM
The estimate for compound 4 lay 1.5-fold (0.16 log units) below the measured number; the measured number falls inside the stated range.
By their numbers in this assay, from the lowest: compound 3; then compounds 1 and 4 (each within the scatter of the next). At a limit, above all of these: compound 2.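

In this assay, among these compounds, relocating one chlorine with the atoms unchanged still moves the number, a 3.0-fold higher number from compound 3 to compound 4 (0.47 log units; beyond the scatter), so on the amine nitrogen in a ring the arrangement of the two chlorines counts by itself, which no earlier step could separate from a change of substituent. The lead of 3,5-dichlorophenyl is therefore not shared by every dichlorophenyl group: a 1.2-fold higher number from compound 1 to compound 4 (0.09 log units; within the scatter), while an at least 8.0-fold lower number from compound 2 to compound 4 (0.90 log units; beyond the scatter), which is a bound only. Compound 2 reads a limit of the assay and not a number: the limit of > 1000 nM in this assay, at which 1 of the 4 values shown sits.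

The compounds shown leave open how much of the lead of 3,5-dichlorophenyl needs both chlorines, since a phenyl group with a single chlorine has no reading here. They also leave open whether a methoxy group, a nitrile or an amine in place of the chlorines would hold the number near that of compound 3, 41.8 nM, and whether the same order of aryl groups would survive a change elsewhere on the shared core.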